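The compounds below may be only part of what the source reports. "The series", "measured", "known", "first", "only" and "open" are said of these compounds alone.

Working notes on the series. In a functional assay on MCF7 cells (Homo sapiens) for cytotoxicity, read by MTT assay, with a stated time of 72 h (on this read-out lower numbers stand for stronger inhibition and higher numbers for weaker inhibition), compound 2 `Cc1cc(-c2ccccc2)n(/C(N)=N/S(=O)(=O)c2cc(C)c(Cl)cc2SCc2ccc(C(F)(F)F)cc2)n1` gives 16000 nM. Compound 1 `Cc1cc(-c2ccccc2)n(/C(N)=N/S(=O)(=O)c2cc(C)c(Cl)cc2SCc2cccc3ccccc23)n1` differs from it only by naphthalen-1-yl in place of 4-(trifluoromethyl)phenyl on a saturated chain carbon bound to a sulfur, and in this assay compound 1 gives 170000 nM, so the change made an 11-fold higher number from compound 2 to compound 1 (1.03 log units; beyond the scatter). Compound 3 `Cc1cc(S(=O)(=O)/N=C(\N)n2nccc2-c2ccccc2)c(SCc2ccc(C(F)(F)F)cc2)cc1Cl` carries a different core: the difference from compound 2 is hydrogen in place of methyl on an aromatic carbon, and in this assay compound 3 gives 25000 nM, a step of a 1.6-fold higher number from compound 2 to compound 3 (0.19 log units; within the scatter).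

Compound 4 `Cc1cc(S(=O)(=O)/N=C(\N)n2nccc2-c2ccccc2)c(SCc2cccc3ccccc23)cc1Cl` is not yet measured. It differs from compound 3 by naphthalen-1-yl in place of 4-(trifluoromethyl)phenyl on a saturated chain carbon bound to a sulfur, which is the same change, at a place described in the same words, as the one from compound 2 to compound 1; it occurs twice among these four compounds. For compound 4 the step from compound 3 is expected to be about a 10-fold higher number from compound 3 to compound 4 (1.00 log units; beyond the scatter). For the measured compounds named here, this rests on compound 2 and compound 1 alone, whose step of an 11-fold higher number from compound 2 to compound 1 (1.03 log units; beyond the scatter) is the only measurement of this change, so the expectation carries the uncertainty of a single pair. Compound 4 is therefore estimated at 250000 nM in this assay, between 80000 nM and 800000 nM.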

Compound 4, half-maximal inhibitory concentration: 58000 nM
The estimate for compound 4 lay 4.3-fold (0.63 log units) above the measured number, outside the stated range (below it).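

In this assay, naphthalen-1-yl in place of 4-(trifluoromethyl)phenyl again gives a higher number on the core of compound 3, but the step is smaller, a 2.3-fold higher number from compound 3 to compound 4 (0.37 log units; beyond the scatter), and its size does not carry over from the first core: the same change on two cores in this assay, an 11-fold higher number (1.03 log units; beyond the scatter) from compound 2 to compound 1 and a 2.3-fold higher number (0.37 log units; beyond the scatter) from compound 3 to compound 4, 4.6-fold (0.66 log units) apart, beyond the scatter of two such steps Read the other way round, hydrogen in place of methyl on an aromatic carbon gives a 2.9-fold lower number from compound 1 to compound 4 (0.47 log units; beyond the scatter), so the effect of this change also depends on the group on the saturated chain carbon: the same change on two cores in this assay, a 1.6-fold higher number (0.19 log units; within the scatter) from compound 2 to compound 3 and a 2.9-fold lower number (0.47 log units; beyond the scatter) from compound 1 to compound 4, 4.6-fold (0.66 log units) apart, beyond the scatter of two such steps Across these four compounds the direction of the naphthalen-1-yl change carries from one core to the other while its size does not, and the two comparisons are one set of four values seen from two sides, so they show neither why the steps differ nor how general the difference is.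

From the compounds shown here alone, it remains open whether the direction holds on further cores. Going by these compounds, it is also open how an amine, a carboxylic acid or a longer alkyl chain would behave on the saturated chain carbon bound to the sulfur.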